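Replacing fluoro with methoxy in compound 2

This account rests on a few compounds, and the source may have more. Where it says the series, first, only, none or still open, it means among the compounds named here.

Compound 1 `Nc1ccccc1NC(=O)c1ccc(CNC(=O)c2n[nH]cc2NC(=O)c2c(F)cccc2Cl)cc1` gives 700 nM
Compound 2 `Nc1ccccc1NC(=O)c1ccc(CNC(=O)c2n[nH]cc2NC(=O)c2ccccc2F)cc1` gives 4800 nM

In a functional assay on HCT-116 cells (Homo sapiens) for inhibition, read by CCK-8 assay, with a stated time of 72 h (a lower number here means a stronger inhibitor, a higher number a weaker inhibitor), compound 2 stands at 4800 nM as the higher of the two numbers, beyond the scatter from compound 1. Compound 3 `COc1ccccc1C(=O)Nc1c[nH]nc1C(=O)NCc1ccc(C(=O)Nc2ccccc2N)cc1` has methoxy in place of fluoro on an aromatic carbon and has not yet been measured. Within the data shown here, one measured step bears on it, the modest 6.9-fold higher number from compound 1 to compound 2 (0.84 log units; beyond the scatter) with hydrogen in place of chloro on an aromatic carbon. Among the measured compounds shown here, no methoxy compound has been measured, so only a smaller step towards a lower number is expected (a 1.6-fold lower number from compound 2 to compound 3 (0.20 log units; within the scatter)) here. The expected value for compound 3 is 3000 nM (estimated range 900 nM to 10000 nM).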

Compound 3, half-maximal inhibitory concentration: 3680 nM
For compound 3 the middle estimate is 1.2-fold (0.09 log units) below the measured one; low and high end bracket the measured number.
By their numbers in this assay, from the lowest: compound 1; then compounds 3 and 2 (each within the scatter of the next).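

On this aromatic carbon, ortho to a large group, methoxy and fluoro cannot be told apart, with a 1.3-fold lower number from compound 2 to compound 3 (0.12 log units; within the scatter). The 2-chloro-6-fluorophenyl group keeps its lead over 2-methoxyphenyl, with a 5.3-fold higher number from compound 1 to compound 3 (0.72 log units; beyond the scatter), so methoxy does not recover what the earlier loss of chloro cost. No supporting data offer an account of this result.

From the compounds shown here alone, it remains open whether methoxy would behave the same way on a ring that also carries chloro, and whether an amine or a hydroxyl group in this place would match methoxy and fluoro.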